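A few compounds are considered here, and "the series" means these few. Any claim that something is new, unique, unknown or untested is made for them only; others in the source may bear on it.

Measured compounds in an ADME assay on microsomes (Rattus norvegicus) for metabolic stability; on this read-out lower numbers stand for a shorter-lived compound and higher numbers for a longer-lived compound:

- Compound 1 `CC[C@@H]1NC(=O)[C@H](CCCNC(=N)N)NC(=O)[C@](C)(NC(=O)C(C)C)CCCNC(=O)[C@@H](c2ccccc2)NC1=O`: compound 1 gives > 1 h in this assay, a limit of the assay rather than a number.
- Compound 2 `CC[C@@H]1NC(=O)[C@H](CCCNC(=N)NC)NC(=O)[C@](C)(NC(=O)C(C)C)CCNC(=O)[C@@H](c2ccccc2)NC1=O`: compound 2 gives > 1 h in this assay, again a limit of the assay.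
- Compound 3 `CC[C@@H]1NC(=O)[C@H](CCCNC(=N)N)NC(=O)[C@](C)(NC(=O)C(C)C)CCCCN(C)C(=O)[C@@H](c2ccc(F)cc2)NC1=O`: compound 3 gives > 1 h in this assay, also a limit of the assay.

Compound 3 therefore stands only as a limit in this assay, with no number behind it. Among the measured compounds shown here, the same holds for every value shown: all three sit at the limit of > 1 h in this assay, at which 3 of the 3 values shown sit, so no ordering among compound 1, compound 2 and compound 3 can be read from this read-out, and no step between two measured compounds that differ in one place is available.

Compound 4 `CC[C@@H]1NC(=O)[C@H](CCCNC(=N)N)NC(=O)[C@](C)(NC(=O)C(C)C)CCCCN(C)C(=O)[C@@H](c2ccccc2)NC1=O` is the next member to go into this assay. Its change from compound 3 is hydrogen in place of fluoro on an aromatic carbon.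

With every shown value at the limit and no measured step to lean on, the expected step from compound 3 to compound 4 in this assay is a step that the limit leaves unreadable from compound 3 to compound 4, none beyond the scatter. Compound 4 is expected to give about 1.5 h in this assay, within a range of 0.6 h to 4 h, most likely reported again as the limit.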

Compound 4, half-life: > 1 h
Compound 4 was reported as a limit (the forecaster's own chance of this, stated with the estimate: 80%); the middle value is on the limit's open side.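

No step between compound 3 and compound 4 can be read in this assay, as both results are limits of the assay: the limit of > 1 h in this assay, at which 4 of the 4 values shown sit.

The compounds shown leave open how far apart their half-lives lie, and whether going from 4-fluorophenyl to phenyl changes the read-out at all.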